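Methyl on a Ring Nitrogen: From Compound 2 to Compound 3

The source may hold more compounds than are shown below. What is called first, only, known or untested is meant among the compounds shown, and "the series" means these compounds.

Measured so far:
- compound 1, `Cn1cc(C(=O)c2nc3ccc(F)cc3n2C)c2cccc(F)c21`: 1.21 nM in an assay on HepG2 cells with Proprotein convertase subtilisin/kexin type 9 (Homo sapiens) as the target, read by ELISA, with a stated time of 24 h; on this read-out lower numbers stand for an effect already at smaller amounts and higher numbers for an effect only at larger amounts of compound
- compound 2, `O=C(c1nc2ccc(F)cc2[nH]1)c1c[nH]c2c(F)cccc12`: 2.46 nM in this assay

Both compounds share a core in which two fused ring systems are joined through a carbonyl. Compound 1 carries a methyl group on each ring nitrogen, while compound 2 has a hydrogen on both. Of the two numbers measured in this assay, compound 2 stands highest, and the gap to compound 1, which gives the lower number, lies beyond the usual scatter of repeated measurements.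

Compound 3, `Cn1c(C(=O)c2c[nH]c3c(F)cccc23)nc2ccc(F)cc21`, differs from compound 2 in one place: methyl in place of hydrogen on an aromatic nitrogen. Among the measured compounds shown here, only one of the two ring nitrogens receives the methyl, so compound 3 sits between compound 2 and compound 1 in its substitution. For the measured compounds named here, no measured pair isolates this single change. Since compound 1 with both methyls gives 1.21 nM and compound 2 with neither gives 2.46 nM, a modest move toward a lower number is expected, though one that may stay within the scatter. The expected step in this assay is a 1.4-fold lower number from compound 2 to compound 3 (0.14 log units; within the scatter). For compound 3 the estimate in this assay is 1.8 nM, with a range from 0.8 nM to 4.5 nM.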

Compound 3, half-maximal effective concentration: 0.15 nM
For compound 3 the middle estimate is 12-fold (1.08 log units) above the measured one; measured number below the stated range.
By their numbers in this assay, from the lowest: compound 3; then compound 1; then compound 2.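

Putting a methyl in place of hydrogen on the aromatic nitrogen of the five-membered aromatic ring with 2 nitrogen gives a 16-fold lower number from compound 2 to compound 3 (1.21 log units; beyond the scatter) in this assay and shows that this single position matters far more than compound 1 and compound 2 could reveal on their own. The methyl on the other ring nitrogen does not add to this gain, as hydrogen in place of that methyl gives an 8.1-fold lower number from compound 1 to compound 3 (0.91 log units; beyond the scatter) and the lowest number of the three belongs to the compound with only one methyl. Nothing measured here explains why either change acts as it does.

The compounds shown leave open whether the gain is specific to methyl or would persist with an ethyl group or a longer chain on the same nitrogen. They also cannot say whether a larger group on the other ring nitrogen, such as an ethyl group, would raise the number as the methyl there does.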